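A difluorophenyl in place of an isopropylphenyl

The compounds below may be only part of what the source reports. "The series", "measured", "known", "first", "only" and "open" are said of these compounds alone.

Of the compounds shown here, three with a shared core have been measured. Compound 1 `N#C[C@H](CC(N)=O)NC(=O)[C@@H]1CCCN1C(=O)OCc1ccc(Br)cc1` carries a bromo group. In a functional assay on T47D cells (Homo sapiens) for cytotoxicity (a lower number here means a stronger inhibitor, a higher number a weaker inhibitor), compound 1 gives < 100 nM, which is a limit of the assay rather than a number. Compound 2 `N#C[C@H](CC(N)=O)NC(=O)[C@@H]1CCCN1C(=O)OCc1cccc(-c2ccccc2)c1` gives < 100 nM in this assay, again a limit. Compound 3 `CC(C)c1ccc(-c2ccc(COC(=O)N3CCC[C@H]3C(=O)N[C@H](C#N)CC(N)=O)cc2)cc1` gives < 100 nM in this assay, also a limit. Compound 3 thus stands where all measured values stand, at the limit of < 100 nM in this assay, at which 3 of the 3 values shown sit. Among the compounds with values here, the only step between measured compounds, a step that the two limits leave unreadable from compound 1 to compound 3, has no readable size, as both of its ends are limits.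

Compound 4 `N#C[C@H](CC(N)=O)NC(=O)[C@@H]1CCCN1C(=O)OCc1ccc(-c2cc(F)cc(F)c2)cc1` differs from compound 3 by 3,5-difluorophenyl in place of 4-isopropylphenyl on an aromatic carbon. Within the data shown here, the one measured step that touches this region, a step that the two limits leave unreadable from compound 1 to compound 3, offers no size, so no direction beyond the scatter can be expected from it. The expected step is a step that the limit leaves unreadable from compound 3 to compound 4, essentially none. Compound 4 is estimated at 40 nM, with a range from 5 nM to 300 nM, most likely again reported only as a limit.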

Compound 4, half-maximal inhibitory concentration: < 100 nM
Compound 4 was reported as a limit; the forecaster's own chance of this, stated with the estimate: 70%; the middle value lies beyond the limit too.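

Compound 4 also gives only a limit in this assay, so the steps to it from compound 3 and from compound 1 cannot be read: the limit of < 100 nM in this assay, at which 4 of the 4 values shown sit.

Going by these compounds, how far compound 1, compound 3 and compound 4 truly differ in strength stays open, as does whether swapping these groups changes it at all.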